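This account rests on a few compounds, and the source may have more. Where it says the series, first, only, none or still open, it means among the compounds named here.

Measured so far in a functional assay on HeLa cells (Homo sapiens) for antiproliferative activity, read by sulforhodamine B assay, with a stated time of 72 h; on this read-out higher numbers stand for weaker inhibition and lower numbers for stronger inhibition:
- Compound 1 `FC(F)(F)c1ccc(/C=C\c2cc3ccccc3nc2Cl)cc1`: 4220 nM
- Compound 2 `FC(F)(F)c1ccc(/C=C\c2cc3ccc(Cl)cc3nc2Cl)cc1`: 12600 nM

Compound 1 has the lower number of the two, so it is the stronger inhibitor so far. Compound 3 `FC(F)(F)c1ccc(/C=C\c2cc3ccccc3nc2Cl)c(C(F)(F)F)c1` keeps the core of compound 1, with one change: trifluoromethyl in place of hydrogen on an aromatic carbon. For the measured compounds named here, the only measured step that bears on this is a 3.0-fold higher number from compound 1 to compound 2 (0.48 log units; beyond the scatter), a modest change from chloro in place of hydrogen on an aromatic carbon. It involves a different group, so it is only a loose guide. In this assay the expected change is again modest and towards weaker inhibition, an estimated 1.9-fold higher number from compound 1 to compound 3 (0.28 log units; within the scatter). The estimate for compound 3 is 8000 nM, with an expected range of 2500 nM to 25000 nM.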

Compound 3, half-maximal inhibitory concentration: 35900 nM
The estimate for compound 3 lay 4.5-fold (0.65 log units) below the measured number; the measured number lies above the stated range.
By their numbers in this assay, from the lowest: compound 1; then compound 2; then compound 3.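

Placed on the six-membered aromatic ring of carbon only, ortho to a large group and meta to a trifluoromethyl group, a second trifluoromethyl gives an 8.5-fold higher number from compound 1 to compound 3 (0.93 log units; beyond the scatter) in this assay. For the compounds shown here, this is the first measured change on that ring, and it shows that this position does not accept this group without a clear loss of inhibition. Nothing available explains that loss. As far as these compounds go, it remains open whether a smaller substituent, such as a fluorine atom or a methyl group, would be better accepted at this position. An amine or a methoxy group there is also an open case.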